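The compounds below may be only part of what the source reports. "The series", "measured", "known", "first", "only" and "open" are said of these compounds alone.

Measured compounds in a functional assay on MCF7 cells (Homo sapiens) for inhibition, read by fluorescence, with a stated time of 72 h; on this read-out higher numbers stand for weaker inhibition of growth and lower numbers for stronger inhibition of growth:
compound 1 `CCCCn1cnc2c(Nc3ccc(Cl)cc3)nc(N[C@H]3CC[C@H](N)CC3)nc21` gives 2100 nM
compound 2 `CCCCCCn1cnc2c(Nc3ccc(Cl)cc3)nc(N[C@H]3CC[C@H](N)CC3)nc21` gives 4200 nM
compound 3 `N[C@H]1CC[C@H](Nc2nc(Nc3ccc(Cl)cc3)c3ncn(C4CCCCC4)c3n2)CC1` gives 2300 nM

Compound 2 has the highest of the three numbers, but the other two sit close to it: a 2.0-fold higher number from compound 1 to compound 2 (0.30 log units; within the scatter) and a 1.8-fold lower number from compound 2 to compound 3 (0.26 log units; within the scatter) are both inside the scatter, as is a 1.1-fold higher number from compound 1 to compound 3 (0.04 log units; within the scatter). On these numbers the three compounds cannot be told apart.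

Compound 4 `CCCCCCn1cnc2c(Nc3cc(OC)cc(OC)c3)nc(N[C@H]3CC[C@H](N)CC3)nc21` is not yet measured. It differs from compound 2 in one place: 3,5-dimethoxyphenyl in place of 4-chlorophenyl on a nitrogen on an aromatic ring. Every measured step alters the group on the other aromatic nitrogen of the shared core, butyl against hexyl or cyclohexyl, and leaves the 4-chlorophenyl untouched; all three of those steps stayed within the scatter. Within the data shown here, no measured step bears on the change from compound 2 to compound 4, so the data give nothing to set its size or direction from, and the range around any estimate has to be wide.

Compound 4 is therefore expected near its parent, at 5000 nM, with a range of 1500 nM to 17000 nM. That estimate means a step of a 1.2-fold higher number from compound 2 to compound 4 (0.08 log units; within the scatter), expected not to exceed the scatter in either direction.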

Compound 4, concentration for 50% growth inhibition: 3500 nM
Beside the measured number, compound 4's estimate is 1.4-fold (0.15 log units) above it; the measured number falls inside the stated range.
By their numbers in this assay, from the lowest: compounds 1, 3, 4 and 2 (each within the scatter of the next).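

In this assay, among these compounds, the first measured change to the aryl group on the nitrogen, 3,5-dimethoxyphenyl in place of 4-chlorophenyl on a nitrogen on an aromatic ring, gives a 1.2-fold lower number from compound 2 to compound 4 (0.08 log units; within the scatter). Among the compounds shown here, earlier steps varied only the group on the other aromatic nitrogen, so this is the first sign that the aryl position can also be changed without a step beyond the scatter, even with the loss of chlorine, a rise from 7 to 10 heavy atoms and the arrival of 2 hydrogen-bond acceptors. The reading rests on one pair carrying hexyl, and nothing available accounts for the result.

It remains open whether the same change would also stay within the scatter with butyl or cyclohexyl on the other aromatic nitrogen, since the 3,5-dimethoxyphenyl group is shown only with hexyl. Also open is whether any aryl group at this position, such as unsubstituted phenyl, 4-methoxyphenyl, 3,5-dichlorophenyl or a phenyl bearing a carboxylic acid, would give a step beyond the scatter, as no step shown so far does.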